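A few compounds are considered here, and "the series" means these few. Any claim that something is new, unique, unknown or untested is made for them only; others in the source may bear on it.

Measured in a physicochemical assay for lipophilicity, read by HPLC, measured as chromatographic lipophilicity, at pH 7.4; a lower number here means a more polar compound, a higher number a more lipophilic compound:
compound 1 `O=C(c1ccccc1)N1CCC(C(=O)N2N=CCC2c2ccccc2)CC1` gives 4.4
compound 2 `O=C(C1CCN(c2ccccc2)CC1)N1N=CCC1c1ccccc1` gives 6.3
compound 3 `O=C(c1c[nH]nn1)N1CCC(C(=O)N2N=CCC2c2ccccc2)CC1` gives 2

Compound 3 stands lowest of the three in this assay, clearly under the other two. Compound 4 `O=C(c1ccccn1)N1CCC(C(=O)N2N=CCC2c2ccccc2)CC1` differs from it as follows: pyridin-2-yl in place of 1H-1,2,3-triazol-4-yl on a carbonyl carbon. In words, pyridin-2-yl sits in place of 1H-1,2,3-triazol-4-yl on a carbonyl carbon. Among the measured compounds shown here, the nearest precedent is the large step of a number 2.40 log units lower from compound 1 to compound 3 (beyond the scatter), made at this same place. The steps of a number 1.90 log units higher from compound 1 to compound 2 (beyond the scatter) and a number 4.30 log units lower from compound 2 to compound 3 (beyond the scatter), also large, change the group on the amine nitrogen and bear less directly. A moderate rise is therefore expected, smaller than the distance separating the two measured carbonyl substituents. The expected step is a number 1.40 log units higher from compound 3 to compound 4 (beyond the scatter). For compound 4 the estimated value is 3.4, within an expected range of 2.8 to 4.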

Compound 4, distribution coefficient: 3.1
Beside the measured number, compound 4's estimate is 0.30 log units above it; measured number inside the range.
By their numbers in this assay, from the lowest: compound 3; then compound 4; then compound 1; then compound 2.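

At the carbonyl carbon, pyridin-2-yl gives a number 1.30 log units lower from compound 1 to compound 4 (beyond the scatter) and a number 1.10 log units higher from compound 3 to compound 4 (beyond the scatter) in this assay and so takes a middle place among the three substituents measured there. With (pyridin-2-yl)carbonyl in place of phenyl on the amine nitrogen in a ring, the result is a number 3.20 log units lower from compound 2 to compound 4 (beyond the scatter) and the gap to that compound stays wide. The compounds shown leave open whether pyridin-3-yl would read like pyridin-2-yl, and how an amine or a carboxylic acid on the pyridine ring would shift the number. Nothing available speaks to the cause of these steps.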